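Series notes: sulfanyl arm change from compound 2 to compound 3

The compounds below may be only part of what the source reports. "The series", "measured", "known", "first", "only" and "open" are said of these compounds alone.

Measured compounds:
compound 1 `COc1ccc(-n2c(SCc3ccc(F)cc3)nnc2-c2cc(OC)c(OC)c(OC)c2)cc1`: 35000 nM
compound 2 `COc1cc(-c2nnc(SCc3ccc(F)cc3)n2-c2ccc(N(C)C)cc2)cc(OC)c1OC`: 26400 nM

In a functional assay on HepG2 cells (Homo sapiens) for inhibition, read by MTT assay, with a stated time of 48 h (a higher number here means a weaker inhibitor, a lower number a stronger inhibitor), compound 2 gives 26400 nM, the smaller of the two numbers shown, while compound 1 gives 35000 nM; the step of a 1.3-fold lower number from compound 1 to compound 2 (0.12 log units; within the scatter) is within the scatter, so neither compound can be called the stronger inhibitor.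

Compound 3 `COc1cc(-c2nnc(SCC(=O)Nc3ccc(Cl)cc3)n2-c2ccc(N(C)C)cc2)cc(OC)c1OC` has not been measured. It differs from compound 2 in one place: (4-chlorophenyl)carbamoyl in place of 4-fluorophenyl on a saturated chain carbon bound to a sulfur. No measured step bears on this change; the single step shown, from compound 1 to compound 2, concerns a different place and was within the scatter. The shared core and the trimethoxyphenyl and dimethylaminophenyl parts are unchanged.

Going by the values given here, with no comparable step available, compound 3 is expected to give about 25000 nM in this assay, within 8000 nM to 80000 nM; the estimated step of a 1.1-fold lower number from compound 2 to compound 3 (0.02 log units; within the scatter) is taken as none beyond the scatter.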

Compound 3, half-maximal inhibitory concentration: > 60000 nM
Compound 3: no number, only a limit (the forecaster's own chance of this, stated with the estimate: 15%); at least 2.4-fold (0.38 log units) between middle value and limit.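

Going by these compounds alone, replacing 4-fluorobenzyl with ((4-chlorophenyl)carbamoyl)methyl on the sulfanyl arm gives, in this assay, an at least 2.2-fold higher number from compound 2 to compound 3 (0.35 log units; beyond the scatter); the only earlier step, dimethylamino in place of methoxy on an aromatic carbon, stayed within the scatter, so this arm is the first place where a change is readable. The entry for compound 3 is a limit of the assay and not a number: the limit of > 60000 nM in this assay, at which 1 of the 3 values shown sits. The step therefore gives a direction and a minimum size, not a full size.

This change brings in the carbamoyl link and swaps fluorine for chlorine in one move, and the compounds shown do not separate the two. A 4-chlorobenzyl arm or a (phenylcarbamoyl)methyl arm on the same sulfur would tell them apart.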